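A few compounds are considered here, and "the series" means these few. Any claim that something is new, unique, unknown or untested is made for them only; others in the source may bear on it.

Measured in a functional assay with Homo sapiens as the target; a higher number here means a weaker inhibitor, a lower number a stronger inhibitor:
- compound 1 `CC(C)[C@H](NC(=O)COc1cccc2ccccc12)C(=O)N[C@@H](CC(=O)O)C(=O)COc1ccc(-c2ccccc2)cc1`: 38700 nM
- compound 2 `CC(C)[C@H](NC(=O)COc1cccc2ccccc12)C(=O)N[C@@H](CC(=O)O)C(=O)COc1cccc(C(F)(F)F)c1`: 16600 nM

Compound 1 holds the higher of the two numbers in this assay. Compound 3 `CC(C)[C@H](NC(=O)COc1cccc2ccccc12)C(=O)N[C@@H](CC(=O)O)C(=O)COc1ccc(Oc2ccc(C(F)(F)F)cc2)cc1` has not been measured and departs from compound 1 by 4-(trifluoromethyl)phenoxy in place of phenyl on an aromatic carbon. Among the compounds with values here, the only measured step, a 2.3-fold lower number from compound 1 to compound 2 (0.37 log units; beyond the scatter), is modest and bears only loosely, since it exchanged the whole 4-phenylphenyl group. It therefore gives no firm direction, and no clear change beyond the scatter is expected. The expected step is a 1.3-fold lower number from compound 1 to compound 3 (0.11 log units; within the scatter). Compound 3 is estimated at 30000 nM, with an expected range of 10000 nM to 80000 nM.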

Compound 3, half-maximal inhibitory concentration: 24900 nM
The estimate for compound 3 lay 1.2-fold (0.08 log units) above the measured number, and the stated range covers the measured number.
By their numbers in this assay, from the lowest: compounds 2, 3 and 1 (each within the scatter of the next, the first and the last beyond it).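

On the aromatic carbon para to a large group, replacing phenyl with the larger 4-(trifluoromethyl)phenoxy, which has 11 heavy atoms rather than 6 and adds a hydrogen-bond acceptor, gives a 1.6-fold lower number from compound 1 to compound 3 (0.19 log units; within the scatter) in this assay and so leaves the number unchanged within the scatter. This position therefore accepts the larger group, with its added oxygen and fluorine atoms, without a clear change in this assay. Nothing measured here explains this result.

The compounds shown leave open whether an amine or a carboxylic acid on this aromatic carbon would move the number beyond the scatter.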